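A few compounds are considered here, and "the series" means these few. Any claim that something is new, unique, unknown or untested is made for them only; others in the source may bear on it.

Measured compounds:
- compound 1 `NC(=O)c1c(NC(=O)c2ccccc2Cl)sc2c1CCN(Cc1ccccc1F)C2`: 21800 nM
- compound 2 `Cc1ccc(C(=O)Nc2sc3c(c2C(N)=O)CCN(Cc2ccc(Cl)cc2Cl)C3)cc1`: 19900 nM
- compound 3 `NC(=O)c1c(NC(=O)c2ccccc2F)sc2c1CCN(Cc1ccc(Cl)cc1Cl)C2`: 13100 nM

In a functional assay on HL-60 cells (Homo sapiens) for antiproliferative activity, with a stated time of 24 h (on this read-out higher numbers stand for weaker inhibition and lower numbers for stronger inhibition), compound 1 gives 21800 nM, the highest of the three numbers, yet its gaps to compound 2 and compound 3 both sit within the scatter, so the three cannot be ordered. For the measured compounds named here, the only measured step, a 1.5-fold lower number from compound 2 to compound 3 (0.18 log units; within the scatter), concerns the group on the carbonyl carbon and does not touch the amine nitrogen in the ring.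

Compound 4 `CSc1ccccc1NC(=S)N1CCc2c(sc(NC(=O)c3ccccc3Cl)c2C(N)=O)C1` differs from compound 1 as follows: a group of 11 heavy atoms (8 carbon, 1 nitrogen, 2 sulfur; one six-membered aromatic ring of carbon only) in place of a group of 8 heavy atoms (7 carbon, 1 fluorine; one six-membered aromatic ring of carbon only), on an amine nitrogen in a ring

Going by the values given here, no measured step bears on a change at this place, so there is no basis for expecting a shift beyond the scatter. Compound 4 is therefore estimated at 20000 nM, range 5000 nM to 70000 nM, an expected step of a 1.1-fold lower number from compound 1 to compound 4 (0.04 log units; within the scatter).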

Compound 4, half-maximal inhibitory concentration: 14600 nM
Estimate against measurement, compound 4: 1.4-fold (0.14 log units) above; the measured number falls inside the stated range.
By their numbers in this assay, from the lowest: compounds 3, 4, 2 and 1 (each within the scatter of the next).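

At the amine nitrogen in a ring, swapping 2-fluorobenzyl for the group of 11 heavy atoms, which brings a hydrogen-bond donor and a double bond outside aromatic rings, gives in this assay a 1.5-fold lower number from compound 1 to compound 4 (0.17 log units; within the scatter) and no readable shift. For this pair, then, the position accepts a very different group without leaving the scatter. No measurement at hand bears on this result.

Going by these compounds, whether an aminoethyl chain or a carboxylic acid on this nitrogen would move the number beyond the scatter remains open. Also open, on these data alone, is whether the same swap behaves alike with the carbonyl groups of compound 2 and compound 3.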